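Shortening the Side Chain on a Shared Core

A few compounds are considered here, and "the series" means these few. Any claim that something is new, unique, unknown or untested is made for them only; others in the source may bear on it.

Three compounds share one core and differ only in the chain attached to the amide-type nitrogen. Compound 1 `CC(C)(C)OC(=O)NCCNC(=O)CN1CN(c2ccccc2)C2(CCN(C(=O)c3ccc(C4CCCCC4)cc3)CC2)C1=O` gives 5500 nM in an assay on HEK293 cells for displacement of a labelled ligand from NPC1-like intracellular cholesterol transporter 1 (Homo sapiens); a lower number here means a stronger inhibitor, a higher number a weaker inhibitor. Compound 2 `COC(=O)CCNC(=O)CN1CN(c2ccccc2)C2(CCN(C(=O)c3ccc(C4CCCCC4)cc3)CC2)C1=O` gives 12900 nM in this assay, and compound 3 `CS(=O)(=O)NCCCNC(=O)CN1CN(c2ccccc2)C2(CCN(C(=O)c3ccc(C4CCCCC4)cc3)CC2)C1=O` gives 3800 nM. Compound 3 thus shows the lowest of the three numbers, with compound 1 within the scatter of it and compound 2 beyond it. The step of a 1.4-fold lower number from compound 1 to compound 3 (0.16 log units; within the scatter) stayed within the scatter, while a 2.3-fold higher number from compound 1 to compound 2 (0.37 log units; beyond the scatter) and a 3.4-fold lower number from compound 2 to compound 3 (0.53 log units; beyond the scatter) were modest. Compound 4 `O=C(CN1CN(c2ccccc2)C2(CCN(C(=O)c3ccc(C4CCCCC4)cc3)CC2)C1=O)NCO` carries hydroxy in place of 2-(methanesulfonamido)ethyl on a saturated chain carbon bound to an amide-type nitrogen. All three measured steps exchanged one end group for another at the far end of the chain; none removed most of the chain, so the step to compound 4 is only loosely bracketed by them. Because those swaps moved the number by no more than a 3.4-fold lower number from compound 2 to compound 3 (0.53 log units; beyond the scatter), a step of similar size is expected here, more likely toward a higher number. Compound 4 is therefore estimated at 7000 nM, between 2500 nM and 20000 nM, an expected step of a 1.8-fold higher number from compound 3 to compound 4 (0.27 log units; within the scatter).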

Compound 4, half-maximal inhibitory concentration: 8300 nM
The estimate for compound 4 lay 1.2-fold (0.07 log units) below the measured number; measured number inside the range.
By their numbers in this assay, from the lowest: compounds 3, 1, 4 and 2 (each within the scatter of the next, the first and the last beyond it).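

Replacing 2-(methanesulfonamido)ethyl with hydroxy on this saturated chain carbon bound to an amide-type nitrogen removes nearly the whole chain, yet it costs only a modest step (a 2.2-fold higher number from compound 3 to compound 4 (0.34 log units; beyond the scatter)). Compared with the other two long chains, the same short end group stays within the scatter (a 1.6-fold lower number from compound 2 to compound 4 (0.19 log units; within the scatter) and a 1.5-fold higher number from compound 1 to compound 4 (0.18 log units; within the scatter)), so in these compounds a long chain is not needed to keep the number in this range. Nothing measured here explains these steps.

Still open, on these data alone, is whether a chain of intermediate length ending in hydroxy, or an end group such as an amine or a carboxylic acid, would give a lower number. Every step shown is modest or within the scatter, so it also remains unknown whether any group at this position can produce a large change.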